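Diaryl Ureas on a Shared Core Against Colon Cancer Cells

The source may report more compounds than this note shows. Statements on the series, on what has been measured and on what is new or still open speak of the compounds shown alone.

Compound 1, `COc1cc2c(Nc3ccc(NC(=O)Nc4ccccc4)cc3)ncnc2cc1OCc1ccccc1`: > 50000 nM
Compound 2, `COc1cc2c(Nc3ccc(NC(=O)Nc4cccc(Cl)c4)cc3)ncnc2cc1OCc1ccccc1`: > 50000 nM

Compound 1 is the parent of this small set. In a functional assay on HT-29 cells (Homo sapiens) for antiproliferative activity, read by MTT assay, with a stated time of 48 h (a lower number here means a stronger inhibitor, a higher number a weaker inhibitor), compound 1 reaches only a limit of the assay, > 50000 nM. Compound 2 carries chloro in place of hydrogen on an aromatic carbon, and in this assay compound 2 also gives only a limit, > 50000 nM. The step that the two limits leave unreadable from compound 1 to compound 2 therefore cannot be read, and the evidence on the whole set is simply (the limit of > 50000 nM in this assay, at which 2 of the 2 values shown sit).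

Compound 3, `COc1cc2c(Nc3ccc(NC(=O)Nc4ccc(C)cc4)cc3)ncnc2cc1OCc1ccccc1`, differs from compound 2 by 4-methylphenyl in place of 3-chlorophenyl on an amide-type nitrogen. Going by the values given here, the only measured step, from compound 1 to compound 2, is unreadable, so nothing measured shows how large a change this replacement might bring in this assay. Since compound 2 sits at the limit, compound 3 is expected to remain at or near that limit as well, with an estimated step that the limit leaves unreadable from compound 2 to compound 3. The estimate for compound 3 is 80000 nM, between 20000 nM and 300000 nM.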

Compound 3, half-maximal inhibitory concentration: > 50000 nM
Compound 3 ended at the assay's limit; the forecaster's own chance of this, stated with the estimate: 80%; the middle value lies beyond the limit too.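

Compound 3 also gives only a limit in this assay, > 50000 nM, so its steps from compound 1 and from compound 2 cannot be read. The whole set now stands at one value: the limit of > 50000 nM in this assay, at which 3 of the 3 values shown sit.

The compounds shown leave open what change to compound 1 would bring a readable number in this assay, and how much the chloro or methyl group matters there.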